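This account rests on a few compounds, and the source may have more. Where it says the series, first, only, none or still open, it means among the compounds named here.

Compound 1 `O=C(NNc1ccccc1F)c1cccc(NS(=O)(=O)c2cnc(O)nc2O)c1` has been measured in a functional assay on MDA-MB-231 cells (Homo sapiens) for antiproliferative activity, read by MTT assay, with a stated time of 24 h; a higher number here means a weaker inhibitor, a lower number a stronger inhibitor. In this assay compound 1 gives > 20000 nM, which is a limit of the assay. Compound 2 `O=C(NNC(=O)c1ccc(NS(=O)(=O)c2cnc(O)nc2O)cc1)c1ccc(F)cc1` gives > 20000 nM, which is also a limit. Within the data shown here, compound 1 therefore stands at the limit of > 20000 nM in this assay, at which 2 of the 2 values shown sit, and no step between measured compounds can be sized. Compound 3 `Cc1ccc(C(=O)NNC(=O)c2cccc(NS(=O)(=O)c3cnc(O)nc3O)c2)cc1` keeps the core of compound 1 and carries (4-methylphenyl)carbonyl in place of 2-fluorophenyl on an amine nitrogen. With compound 1 resting on its limit of > 20000 nM, no clear gain in this assay is expected from this change, and no direction can be assigned with confidence. The expected step that the limit leaves unreadable from compound 1 to compound 3 is therefore none beyond the scatter. Compound 3 is estimated at about 25000 nM, with an expected range of 10000 nM to 50000 nM, and may well be reported only as a limit.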

Compound 3, half-maximal inhibitory concentration: > 20000 nM
Compound 3: no number, only a limit; the forecaster's own chance of this, stated with the estimate: 75%; the middle value is on the limit's open side.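

In this assay, among these compounds, compound 3 gives > 20000 nM as a limit of the assay, so no step from compound 1 to compound 3 can be read. The compounds shown leave open how far each lies from that limit, since all rest on it: the limit of > 20000 nM in this assay, at which 3 of the 3 values shown sit.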